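Shortening the Side Chain of Compound 1

A few compounds are considered here, and "the series" means these few. Any claim that something is new, unique, unknown or untested is made for them only; others in the source may bear on it.

Of the compounds shown here, three sharing one core have been measured in a functional assay on HepG2 cells (Homo sapiens) for antiproliferative activity, read by CCK-8 assay, with a stated time of 72 h, tested at 8 uM; a higher number here means a stronger effect of the compound at the concentration tested, a lower number a weaker effect. Compound 1 `COC(CCn1cnc2c(NCc3ccc(C(=O)Nc4ccccc4N)cc3)nc(Cl)nc21)OC` gives 34.2% in this assay. Compound 2 `Nc1ccccc1NC(=O)c1ccc(Cn2cnc3c(Nc4ccc(-c5ccccn5)cc4)nc(Cl)nc32)cc1` gives 41.2%, which lies within the scatter of compound 1. Compound 3 `Nc1ccccc1NC(=O)c1ccc(Cn2cnc3c(Nc4cccc(Cl)c4)nc(Cl)nc32)cc1` gives 66.7%, a number beyond the scatter of compound 1. Compound 1 therefore stands lowest of the three, though it cannot be separated from compound 2.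

Going by the values given here, only one step between neighbouring structures has been measured: a number 25.5 percentage points higher from compound 2 to compound 3 (beyond the scatter). That change sits on a nitrogen on an aromatic ring, a different part of the molecule from the side chain that carries the dimethoxymethyl group of compound 1.

Compound 4 `CCCn1cnc2c(NCc3ccc(C(=O)Nc4ccccc4N)cc3)nc(Cl)nc21` differs from compound 1 in one place: methyl in place of dimethoxymethyl on a saturated chain carbon, two bonds along the chain from an aromatic nitrogen

Among the compounds with values here, no measured step touches this chain, so nothing among the three compounds tells how this assay responds to removing the two oxygens from the chain end. The change is small in size and leaves the rest of the structure untouched. The step from compound 1 to compound 4 is therefore expected to be none beyond the scatter, a number 0.8 percentage points higher from compound 1 to compound 4 (within the scatter). For compound 4 the estimated value in this assay is 35%, expected to fall between 20% and 52%.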

Compound 4, a percentage reported as inhibition, at one concentration (the size of the read-out at that concentration, not a potency): 14.1%
The estimate for compound 4 lay 20.9 percentage points above the measured number, and the stated range ends above it.
By their numbers in this assay, from the lowest: compound 4; then compounds 1 and 2 (each within the scatter of the next); then compound 3.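

In this assay, going from the 3,3-dimethoxypropyl chain to the plain propyl chain gives a number 20.1 percentage points lower from compound 1 to compound 4 (beyond the scatter), so the end of this chain is not a silent part of the molecule: a change there alone moves the read-out by more than repeat measurements would. Going by these compounds alone, the earlier compounds could not show this, since their only measured step lay on a nitrogen on an aromatic ring, and this step now shows that the dimethoxymethyl group counts for more at the tested concentration than a simple methyl in its place. No measurement shown bears on the reason for the drop, so its cause remains unknown.

This single step swaps the dimethoxymethyl group for methyl as a whole, so it cannot separate the loss of the oxygens from the loss of the carbons and the shortening of the group. A hydroxyl, an amine or a carboxylic acid at the chain end, or a longer plain chain such as butyl, would help tell these apart.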